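The compounds below may be only part of what the source reports. "The series", "measured", "known", "first", "only" and "open" are said of these compounds alone.

Measured so far in a functional assay on HOS-TE85 cells (Homo sapiens) for inhibition, read by CCK-8 assay, with a stated time of 72 h; a lower number here means a stronger inhibitor, a higher number a weaker inhibitor
- compound 1 `COc1ccccc1N1C(=O)CSC1c1cccc(C(=O)NCCCCn2cncn2)c1` gives > 1000 nM (a limit)
- compound 2 `O=C(NCCCCn1cccn1)c1cccc(C2SCC(=O)N2c2cc(Br)ccn2)c1` gives 105 nM (a number)
- compound 3 `C#Cc1cc(C(=O)NCCCCc2ccccc2)cc(C2SCC(=O)N2c2ccccc2OC)c1` gives 40.8 nM (a number)

The entry for compound 1 is a limit and not a number. Compound 2 has the higher of the two actual numbers, and compound 3 lies lower by a gap beyond the usual scatter.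

In this assay compound 4 `O=C(NCCCCn1cccn1)c1cccc(C2SCC(=O)N2c2ccccn2)c1` has not yet been measured. It differs from compound 2 by hydrogen in place of bromo on an aromatic carbon with hydrogen in place of bromo on an aromatic carbon, so that 4-bromopyridin-2-yl becomes pyridin-2-yl.

For the measured compounds named here, no measured pair isolates this change, so any forecast is loose. A moderate move toward a higher number in this assay is expected, possibly beyond the scatter. The support is thin. Compound 1 also has no bromo and shows > 1000 nM as a limit. Compound 3 also has no bromo and goes against that reading, with 40.8 nM as its value. Both differ from compound 2 in other places as well.

The expected change is a 1.9-fold higher number from compound 2 to compound 4 (0.28 log units; within the scatter) as a rough estimate. For compound 4 the estimated value is 200 nM with an expected range from 55 nM to 750 nM around it.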

Compound 4, half-maximal inhibitory concentration: 60.3 nM
For compound 4 the middle estimate is 3.3-fold (0.52 log units) above the measured one; measured number inside the range.
By their numbers in this assay, from the lowest: compounds 3, 4 and 2 (each within the scatter of the next, the first and the last beyond it). At a limit, above all of these: compound 1.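

In this assay, the change from 4-bromopyridin-2-yl to pyridin-2-yl gives the series its first step that differs in one place: a 1.7-fold lower number from compound 2 to compound 4 (0.24 log units; within the scatter). At this aromatic carbon, opposite the ring nitrogen, hydrogen in place of bromo therefore leaves the two compounds indistinguishable in this assay, and the bromo is not needed for compound 4 to give a measured value in the same range as compound 2. The step holds for the side chain and core shared by these two compounds, while compound 1 remains a limit and not a number, so it adds no size to any comparison: the limit of > 1000 nM in this assay, at which 1 of the 4 values shown sits.

Still open, from the compounds shown here alone, is whether this carbon is as undemanding for other groups, since a single step cannot show whether a chloro, a nitrile, an amine or a carboxylic acid in place of the bromo would stay within the scatter of compound 4. For the compounds shown here, also open is whether the same change reads the same way on the side chains of compound 1 and compound 3, or on a longer chain in place of the one shared by compound 2 and compound 4.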